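A few compounds are considered here, and "the series" means these few. Any claim that something is new, unique, unknown or untested is made for them only; others in the source may bear on it.

Compound 1 `COc1ccc(C2=NN(C3=NC(=O)/C(=C4\C(=O)Nc5ccccc54)S3)C(c3ccc(Cl)cc3)C2)cc1` is the parent of the pair measured so far. In a functional assay on cells (Cancer cell lines, Homo sapiens) for cytotoxicity, read by sulforhodamine B assay, with a stated time of 48 h (a lower number here means a stronger inhibitor of growth, a higher number a weaker inhibitor of growth), compound 1 gives 100000 nM. Compound 2 `COc1ccc(C2=NN(C3=NC(=O)/C(=C4\C(=O)Nc5ccc(Br)cc54)S3)C(c3ccc(Cl)cc3)C2)cc1` carries a bromo on an aromatic carbon of the shared core; in this assay compound 2 gives 130 nM, and the step is a 770-fold lower number from compound 1 to compound 2 (2.89 log units; beyond the scatter). Among the measured compounds shown here, compound 2 therefore stands at the lower of the two numbers, with compound 1 as its only neighbour and a wide gap between them. Compound 3 `COc1ccc(C2=NN(C3=NC(=O)/C(=C4\C(=O)Nc5ccc(Cl)cc54)S3)C(c3ccc(Cl)cc3)C2)cc1` is not yet measured; it differs from compound 2 by chloro in place of bromo on an aromatic carbon. For the measured compounds named here, the only measured step that bears on this change is a 770-fold lower number from compound 1 to compound 2 (2.89 log units; beyond the scatter), which shows that a halogen at this carbon against hydrogen weighs heavily in this assay; no measured pair compares one halogen with another, so the bromo-to-chloro swap has no direct precedent in this set. The expectation is that compound 3 keeps most of what compound 2 gained, with a 1.5-fold higher number from compound 2 to compound 3 (0.19 log units; within the scatter) in this assay, a move within or close to the scatter. The estimate for compound 3 is 200 nM, expected to fall between 60 nM and 700 nM.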

Compound 3, concentration for 50% growth inhibition: 210 nM
For compound 3 the middle estimate is 1.1-fold (0.02 log units) below the measured one, and the stated range covers the measured number.
By their numbers in this assay, from the lowest: compounds 2 and 3 (each within the scatter of the next); then compound 1.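

In this assay, the exchange of bromo for chloro on this aromatic carbon gives a 1.6-fold higher number from compound 2 to compound 3 (0.21 log units; within the scatter), so the two halogens cannot be told apart at this position in this read-out. Against the unsubstituted parent, chloro gives a 480-fold lower number from compound 1 to compound 3 (2.68 log units; beyond the scatter), which shows that the large gain first seen with bromo is not unique to that one halogen and now rests on two compounds rather than one. Nothing measured in this set bears on what lies behind the size of this gain or on why the two halogens sit so close together.

From the compounds shown here alone, whether the gain needs a halogen at all remains open: fluoro, methyl, methoxy or an amine on the same carbon could stay close to compound 2 and compound 3 or fall back towards compound 1. Going by these compounds, all three compounds also share the rest of the core, including its methoxy and chloro substituents, so it is equally open whether the halogen step would hold with a carboxylic acid or a longer chain elsewhere on the scaffold.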